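This account rests on a few compounds, and the source may have more. Where it says the series, first, only, none or still open, it means among the compounds named here.

In an ADME assay on HCT-116 cells (Homo sapiens) for cytotoxicity, read by CellTiter-Glo, with a stated time of 72 h (a higher number here means a weaker inhibitor, a lower number a stronger inhibitor), compound 1 `CC1CCN(C2CCN(S(=O)(=O)c3cccnc3Cl)CC2)CC1` is reported only as a limit, > 10000 nM. Compound 2 `CC1CCN(C2CCN(S(=O)(=O)c3cnc(Cl)s3)CC2)CC1` is likewise reported only as a limit, > 10000 nM. Compound 3 `CC1CCN(C2CCN(S(=O)(=O)c3nccn3C)CC2)CC1` also gives only a limit, > 10000 nM. The three compounds share (the limit of > 10000 nM in this assay, at which 3 of the 3 values shown sit), so compound 3 has no number of its own to start from.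

Compound 4 `CC1CCN(C2CCN(S(=O)(=O)c3cn(C)cn3)CC2)CC1` has the same atoms as compound 3, joined differently, with 1-methyl-1H-imidazol-4-yl in place of 1-methyl-1H-imidazol-2-yl on a sulfonyl sulfur.

The measured steps that bear on this change the group at that same place. They are a step that the two limits leave unreadable from compound 1 to compound 2, a step that the two limits leave unreadable from compound 1 to compound 3 and a step that the two limits leave unreadable from compound 2 to compound 3. None of them has a readable size or direction, so they offer no ground for expecting a shift in this assay. The expected outcome is therefore no change beyond the scatter, and the step expected is a number no higher from compound 3 to compound 4 (the limit leaves the size open). Compound 4 is estimated at 10000 nM, with an expected range from 5000 nM to 20000 nM.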

Compound 4, half-maximal inhibitory concentration: > 10000 nM
Compound 4: only a limit was reported (the forecaster's own chance of this, stated with the estimate: 90%); the middle value lies on the limit itself.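

In this assay compound 4 gives only a limit, > 10000 nM, so no step to it from compound 1, compound 2 or compound 3 can be read: the limit of > 10000 nM in this assay, at which 4 of the 4 values shown sit.

The compounds shown leave open where the true value of each lies, and whether changing the group on the sulfonyl sulfur shifts it at all.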